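A few compounds are considered here, and "the series" means these few. Any claim that something is new, unique, unknown or untested is made for them only; others in the source may bear on it.

In a functional assay on OVCAR-3 cells (Homo sapiens) for cytotoxicity; on this read-out higher numbers stand for weaker inhibition of growth and lower numbers for stronger inhibition of growth:
- compound 1 `CCCCCCNC(=O)c1cc(NCc2cc(O)ccc2O)ccc1O`: 4000 nM
- compound 2 `O=C(NCc1ccccc1)c1cc(NCc2cc(O)ccc2O)ccc1O`: 21000 nM
- compound 3 `CCCCCCCCCCCCNC(=O)c1cc(NCc2cc(O)ccc2O)ccc1O`: not yet measured

Compound 1 has the lower of the two numbers, so it inhibits growth more strongly. Compound 3 differs from it by a longer chain: hexyl in place of hydrogen on a saturated chain carbon, six bonds along the chain from an amide-type nitrogen. Going by the values given here, only one measured step bears on this, and only indirectly: a 5.3-fold higher number from compound 1 to compound 2 (0.72 log units; beyond the scatter). Among the compounds with values here, it shows that changing this chain can move the number modestly, but no measured step lengthens a chain. A modest step is therefore expected, with neither direction favoured. The estimate for compound 3 is 4000 nM, with an expected range from 800 nM to 20000 nM. This estimate means an expected no change at the digits printed from compound 1 to compound 3 (within the scatter).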

Compound 3, concentration for 50% growth inhibition: 1900 nM
The estimate for compound 3 lay 2.1-fold (0.32 log units) above the measured number; measured number inside the range.
By their numbers in this assay, from the lowest: compound 3; then compound 1; then compound 2.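

In this assay, hexyl in place of hydrogen on a saturated chain carbon, six bonds along the chain from an amide-type nitrogen, gives a 2.1-fold lower number from compound 1 to compound 3 (0.32 log units; beyond the scatter), which means stronger inhibition of growth. Unlike the earlier compounds, this pair shows a direction for lengthening this chain, although the step is modest and rests on one pair. Nothing available explains the change.

A single step cannot show whether the number keeps falling as the chain grows. Going by these compounds, a longer chain than that of compound 3, or an amine or a carboxylic acid on this chain, remains open.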